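Nitro in Place of Methyl: What to Expect for Compound 4

A few compounds are considered here, and "the series" means these few. Any claim that something is new, unique, unknown or untested is made for them only; others in the source may bear on it.

Of the compounds shown here, three have so far been measured in a functional assay on ECa-109 cells (Homo sapiens) for antiproliferative activity, read by MTT assay, with a stated time of 72 h; on this read-out higher numbers stand for weaker inhibition and lower numbers for stronger inhibition. Compound 1 `CCCSc1nc(N/N=C(\C)c2ccccc2O)c2nnn(Cc3ccco3)c2n1` gives 5760 nM in this assay, and compound 3 `CCCSc1nc(N/N=C(\C)c2ccccc2O)c2nnn(Cc3cccc(Cl)c3)c2n1` gives 13000 nM. Between these two lies the only measured step, a 2.3-fold higher number from compound 1 to compound 3 (0.35 log units; beyond the scatter), a change on the saturated chain carbon bound to an aromatic nitrogen, not on the aryl group carried by the hydrazone-like linker.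

Compound 2 `CCCSc1nc(N/N=C/c2ccc(C)cc2)c2nnn(Cc3ccccc3)c2n1` stands apart. In this assay compound 2 returns only a limit of the assay, > 64000 nM, not a number, so compound 2 sits at the limit of > 64000 nM in this assay, at which 1 of the 3 values shown sits.

Compound 4 `CCCSc1nc(N/N=C/c2ccc([N+](=O)[O-])cc2)c2nnn(Cc3ccccc3)c2n1` has not yet been measured. It differs from compound 2 by nitro in place of methyl on an aromatic carbon. Among the measured compounds shown here, no measured step touches this part of the shared core: the single step from compound 1 to compound 3 concerns a different place, and compound 2 itself gives only a limit, so there is no measured foothold for a direction. The expectation is therefore a step no larger than the scatter, with compound 4 likely also at or near the limit. Compound 4 is expected to give about 64000 nM in this assay, within a range from 20000 nM to 200000 nM. This estimate means an expected step of a number no higher from compound 2 to compound 4 (the limit leaves the size open).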

Compound 4, half-maximal inhibitory concentration: 6640 nM
The estimate for compound 4 lay 9.6-fold (0.98 log units) above the measured number; the measured number lies below the stated range.
By their numbers in this assay, from the lowest: compounds 1, 4 and 3 (each within the scatter of the next, the first and the last beyond it). At a limit, above all of these: compound 2.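

In this assay, the group on the aromatic ring, at the place para to a large group, turns out to matter: the change from 4-methylphenyl to 4-nitrophenyl gives an at least 9.6-fold lower number from compound 2 to compound 4 (0.98 log units; beyond the scatter). Among the compounds shown here, the earlier compounds offered only one measured step, at the saturated chain carbon, so this is the first sign that the other end of the molecule can also move the read-out, here enough to bring a compound from the limit of the assay to a measured number. The full size of this step cannot be read, since compound 2 has only a limit of the assay and not a number: the limit of > 64000 nM in this assay, at which 1 of the 4 values shown sits.

The compounds shown leave open how an amine or a carboxylic acid at this same place would read, so this single pair cannot separate an effect of gaining nitro from one of losing methyl. They also leave open whether the same change would act alike on a compound carrying furan-2-yl at the chain carbon, as compound 1 does, or whether it holds only with the groups that compound 2 and compound 4 share.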